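From methyl to propyl on compound 1

This account rests on a few compounds, and the source may have more. Where it says the series, first, only, none or still open, it means among the compounds named here.

Among the measured compounds shown here, in a functional assay on A549 cells (Homo sapiens) for antiproliferative activity, read by MTT assay, with a stated time of 96 h (on this read-out higher numbers stand for weaker inhibition of growth and lower numbers for stronger inhibition of growth), compound 1 (`Cc1cc(-c2ccc(F)cc2)n(Cc2ccc(C(=O)NO)cc2)n1`) gives 33000 nM, the highest of the three numbers so far. Compound 2 (`Cc1ccc(-c2cc(C)nn2Cc2ccc(C(=O)NO)cc2)cc1`) gives 12400 nM, and compound 3 (`O=C(CCCCCCNC(=O)c1cc(-c2ccc(F)cc2)[nH]n1)NO`) gives 1980 nM. Compound 4 (`CCCc1cc(-c2ccc(F)cc2)n(Cc2ccc(C(=O)NO)cc2)n1`) differs from compound 1 by ethyl in place of hydrogen on a saturated chain carbon bound to an aromatic carbon, or methyl to propyl. For the measured compounds named here, the only measured step, a 2.7-fold lower number from compound 1 to compound 2 (0.43 log units; beyond the scatter), is methyl in place of fluoro on an aromatic carbon, so it is only a loose guide to size. A modest move to a lower number in this assay is therefore expected, though none beyond the scatter remains possible. The expected change is a 1.7-fold lower number from compound 1 to compound 4 (0.22 log units; within the scatter). For compound 4 the estimated value is 20000 nM, with an expected range of 7000 nM to 55000 nM.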

Compound 4, concentration for 50% growth inhibition: 16000 nM
The estimate for compound 4 lay 1.3-fold (0.10 log units) above the measured number, and the stated range covers the measured number.
By their numbers in this assay, from the lowest: compound 3; then compounds 2 and 4 (each within the scatter of the next); then compound 1.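

In this assay the change from methyl to propyl gives a 2.1-fold lower number from compound 1 to compound 4 (0.31 log units; beyond the scatter) and so shows that this position, the same in compound 1 and compound 2, can carry a longer chain without a rise in the number. The step is modest and points the same way as a 2.7-fold lower number from compound 1 to compound 2 (0.43 log units; beyond the scatter) at another place on the core. Nothing measured here accounts for the step.

As far as these compounds go, whether a longer chain, or an amine or a carboxylic acid on the propyl chain, would lower the number further remains open. So does whether methyl to propyl would give a similar step on the core of compound 2.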